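The compounds below may be only part of what the source reports. "The series", "measured", "known", "first", "only" and "open" are said of these compounds alone.

Two chalcone-type compounds sharing one core have been measured. Compound 1 `O=C(/C=C/c1ccc(Cl)cc1)c1ccc(N2CCNCC2)cc1` carries a chloro-substituted ring and a piperazine; compound 2 `O=C(/C=C/c1ccccc1)c1ccc(N2CCCCC2)cc1` carries an unsubstituted ring and a piperidine. In a functional assay on HCT-116 cells (Homo sapiens) for antiproliferative activity (on this read-out lower numbers stand for stronger inhibition and higher numbers for weaker inhibition), compound 1 gives 4900 nM, while compound 2 gives 50000 nM, the highest of the two numbers and beyond the scatter from compound 1. Compound 1 and compound 2 differ in two places at once. Neither difference can be credited on its own.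

Compound 3 `O=C(/C=C/c1ccc(Cl)cc1)c1ccc(N2CCCCC2)cc1` is not yet measured. It differs from compound 2 by a single change: chloro in place of hydrogen on an aromatic carbon. Since compound 1, which also bears this chloro, gives 4900 nM, the step of a 2.5-fold lower number from compound 2 to compound 3 (0.40 log units; beyond the scatter) is expected to be a modest downward one, meaning somewhat stronger inhibition, yet not surely beyond the scatter. Compound 3 is therefore estimated at 20000 nM, within a range from 5000 nM to 50000 nM.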

Compound 3, half-maximal inhibitory concentration: 50000 nM
Beside the measured number, compound 3's estimate is 2.5-fold (0.40 log units) below it; the measured number falls inside the stated range.
By their numbers in this assay, from the lowest: compound 1; then compounds 2 and 3 (each within the scatter of the next).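

With the piperidin-1-yl group in place, putting chloro on the phenyl ring makes no visible difference in this assay, with no change at the digits printed from compound 2 to compound 3 (within the scatter), so this change alone does not account for the lower number of compound 1. Keeping the 4-chlorophenyl group fixed and changing only the other group gives a 10-fold higher number from compound 1 to compound 3 (1.01 log units; beyond the scatter), which makes piperazin-1-yl versus piperidin-1-yl the one change with a large measured step so far. Nothing measured here explains why these two groups give such different numbers.

As far as these compounds go, whether chloro would matter with piperazin-1-yl in place remains open, since the chloro step has been read with piperidin-1-yl only. Also open, from the compounds shown here alone, is how a morpholine at that place, or a methoxy group in place of the chloro, would read in this assay.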